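The source may report more compounds than this note shows. Statements on the series, on what has been measured and on what is new or still open speak of the compounds shown alone.

Values in a functional assay on DU-145 cells (Homo sapiens) for inhibition, read by trypan blue exclusion, with a stated time of 96 h (a lower number here means a stronger inhibitor of growth, a higher number a weaker inhibitor of growth), so far:
compound 1 `O=C(/C(=C\c1ccc(Br)c(O)c1)S(=O)(=O)c1ccc(Br)cc1)c1ccc(Br)cc1` gives 50000 nM
compound 2 `COc1ccc(/C=C(\C(=O)c2ccc(Br)cc2)S(=O)(=O)Cc2ccc(F)cc2)cc1` gives 25000 nM
compound 3 `O=C(/C(=C\c1c[nH]c2ccccc12)Sc1ccc(Br)cc1)c1ccc(Br)cc1` gives 1000 nM

Compound 1 stands at the high end of these numbers, alongside compound 2, and the two values lie within the scatter of each other. Compound 3 lies beyond the scatter on the lower side of compound 1. It differs from compound 1 in more than one place, so that gap cannot be read as the result of any single change.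

The unmeasured compound 4 `O=C(/C(=C\c1ccc(Br)cc1)S(=O)(=O)c1ccc(Br)cc1)c1ccc(Br)cc1` turns the 4-bromo-3-hydroxyphenyl of compound 1 into 4-bromophenyl. This puts hydrogen in place of hydroxy on an aromatic carbon, ortho to a bromo group and meta to a large group (hydrogen in place of hydroxy on an aromatic carbon).

Among the measured compounds shown here, no measured pair isolates this change. Compound 2 also carries no hydroxy and reads 25000 nM, within the scatter of compound 1, although it differs from compound 1 elsewhere as well. On that thin basis, no step beyond the scatter is expected in this assay, with a slightly lower number as the likelier direction. The expected step is a 1.7-fold lower number from compound 1 to compound 4 (0.22 log units; within the scatter), which stays within the scatter. The estimated value for compound 4 is 30000 nM, with an expected range of 8000 nM to 80000 nM.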

Compound 4, concentration for 50% growth inhibition: 10000 nM
Beside the measured number, compound 4's estimate is 3.0-fold (0.48 log units) above it; low and high end bracket the measured number.
By their numbers in this assay, from the lowest: compound 3; then compound 4; then compounds 2 and 1 (each within the scatter of the next).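

In this assay, among the compounds shown here, the change from 4-bromo-3-hydroxyphenyl to 4-bromophenyl gives a 5.0-fold lower number from compound 1 to compound 4 (0.70 log units; beyond the scatter) and provides the first reading of a single change, as the earlier compounds all differ from one another in more than one place. At this aromatic carbon, ortho to a bromo group and meta to a large group, hydrogen therefore gives a lower number than hydroxy in the core of compound 1, although this pattern rests on one modest step. No measurement available here accounts for the step, so its origin remains unassigned.

The compounds shown leave open whether the step is specific to hydroxy or would also appear with another group on the same carbon, such as methoxy, fluoro or an amine. They also leave open whether the same change would give a similar step in compound 2 or compound 3, each of which differs from compound 4 in more than one place.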